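Amide Substituent Changes on a Shared Core

The source may report more compounds than this note shows. Statements on the series, on what has been measured and on what is new or still open speak of the compounds shown alone.

compound 1: `C#CC(C)OC(=O)c1ccc(C(CC)(CC)c2ccc(OCCC(O)(CC)CC)c(C)c2)n1CC` — > 50000 nM
compound 2: `CCOC(=O)CN(C)C(=O)c1ccc(C(CC)(CC)c2ccc(OCCC(O)(CC)CC)c(C)c2)n1CC` — 3210 nM

In a functional assay on MCF7 cells (Homo sapiens) for antiproliferative activity, read by MTT assay, with a stated time of 48 h (a higher number here means a weaker inhibitor, a lower number a stronger inhibitor), compound 1 gives > 50000 nM, which is a limit of the assay and not a number. Compound 2 gives 3210 nM in this assay, the only number shown among the two values. For the measured compounds named here, the one measured step, an at least 15-fold lower number from compound 1 to compound 2 (1.19 log units; beyond the scatter), is therefore large, with the limit of > 50000 nM in this assay, at which 1 of the 2 values shown sits, as its basis.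

Compound 3 is `CCn1c(C(=O)NC(C)CO)ccc1C(CC)(CC)c1ccc(OCCC(O)(CC)CC)c(C)c1`. Its difference from compound 2 is (1-(hydroxymethyl)ethyl)amino in place of ((ethoxycarbonyl)methyl)(methyl)amino on a carbonyl carbon. The measured step bears only loosely on this change: it swapped an ester for an amide on the carbonyl carbon, whereas compound 3 keeps an amide and alters only the substituent on its nitrogen. Going by the values given here, no step in the set shows how such a change within the amide series reads out, so the expected step of a 1.1-fold lower number from compound 2 to compound 3 (0.03 log units; within the scatter) from compound 2 to compound 3 is not expected to exceed the scatter. Compound 3 is estimated at 3000 nM in this assay, within 1000 nM to 12000 nM.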

Compound 3, half-maximal inhibitory concentration: 12600 nM
Compound 3: middle estimate off by 4.2-fold (0.62 log units), on the low side, outside the stated range (above it).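

Within the amides, the substituent on the nitrogen matters in this assay, with a step of a 3.9-fold higher number from compound 2 to compound 3 (0.59 log units; beyond the scatter) on going to (1-(hydroxymethyl)ethyl)amino on the carbonyl carbon. The earlier step showed only an ester giving way to an amide, so keeping an amide at this place does not by itself fix the reading. The direction of that earlier step holds for the second amide as well, with an at least 3.9-fold lower number from compound 1 to compound 3 (0.59 log units; beyond the scatter) as the new step, though it rests on a limit and not a number: the limit of > 50000 nM in this assay, at which 1 of the 3 values shown sits.

Which part of the change carries the step stays open, since the hydroxymethyl group, the ethoxycarbonyl group and the methyl on the nitrogen all change together. A dimethylamino amide, or a carboxylic acid in place of the ethyl ester, would begin to separate these parts.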